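A few compounds are considered here, and "the series" means these few. Any claim that something is new, unique, unknown or untested is made for them only; others in the source may bear on it.

Compound 1 `COc1cc(Nc2nnc(Cl)c(Nc3cc(OC)c(OC)c(OC)c3)n2)cc(OC)c1OC` and compound 2 `COc1cc(Nc2nc(Nc3ccc4c(ccn4C)c3)nnc2Cl)cc(OC)c1OC` share a common core and differ only in the aromatic group attached to one nitrogen on that core. In a functional assay on PC-3 cells (Homo sapiens) for inhibition, read by MTT assay, with a stated time of 48 h (on this read-out lower numbers stand for stronger inhibition and higher numbers for weaker inhibition), compound 1 gives 34300 nM and compound 2 gives 48500 nM. Compound 2 shows the higher of the two numbers, but its gap to compound 1 lies within the usual scatter, so the two cannot be told apart on these data; both are weak inhibitors on this read-out.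

Compound 3 `COc1cc(Nc2nc(Nc3ccc(Br)cc3)nnc2Cl)cc(OC)c1OC` has not yet been measured. It keeps the core of compound 2 and changes one group: 4-bromophenyl in place of 1-methyl-1H-indol-5-yl on a nitrogen on an aromatic ring. Among the measured compounds shown here, no measured pair here shows the effect of such an exchange, so the size of the step cannot be read from a known example. Compound 1 and compound 2 differ in the same place and still sit within the scatter of each other. On that basis the expected step is a 1.2-fold lower number from compound 2 to compound 3 (0.08 log units; within the scatter), no larger than the scatter and in no particular direction. Compound 3 is therefore expected to give about 40000 nM, with a plausible range from 15000 nM to 110000 nM.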

Compound 3, half-maximal inhibitory concentration: 8990 nM
For compound 3 the middle estimate is 4.4-fold (0.65 log units) above the measured one; the measured number lies below the stated range.
By their numbers in this assay, from the lowest: compound 3; then compounds 1 and 2 (each within the scatter of the next).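

In this assay, the group on this nitrogen proves able to move the number: 4-bromophenyl in place of 1-methyl-1H-indol-5-yl gives a 5.4-fold lower number from compound 2 to compound 3 (0.73 log units; beyond the scatter), a step beyond the scatter and modest in size. The near-equal values of compound 1 and compound 2 gave no sign of this, so the position is not indifferent to what sits on it. The exchange alters several things at once, since the entering group has one ring where the leaving group has two and carries bromine where the leaving group carries nitrogen, and nothing measured here explains the step.

The compounds shown leave open whether the change in number belongs to the bromine or to the loss of the five-membered ring, a question that a plain phenyl or a 4-chlorophenyl on the same nitrogen could help to separate. They also leave open how an amine or a carboxylic acid on that phenyl ring would read, and so whether this position tolerates groups very different from bromine.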